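A few compounds are considered here, and "the series" means these few. Any claim that something is new, unique, unknown or untested is made for them only; others in the source may bear on it.

The measured compounds in an assay on ileum with muscarinic acetylcholine receptor M3 (Cavia porcellus) as the target; a higher number here means a weaker inhibitor, a lower number a stronger inhibitor:
compound 1 `NC(=O)C(CCn1ccnc1)(c1ccccc1)c1ccccc1` gives 5.07 nM
compound 2 `CCc1nccn1CCC(C(N)=O)(c1ccccc1)c1ccccc1` gives 78.1 nM
compound 3 `CCc1ncn(CCC(C(N)=O)(c2ccccc2)c2ccccc2)c1CC` gives 3.98 nM

Compound 3 has the lowest number of the three. Compound 1 sits nearest, and the step of a 1.3-fold lower number from compound 1 to compound 3 (0.11 log units; within the scatter) lies within the scatter, so no order between compound 3 and compound 1 can be read from these numbers. Compound 2 is furthest away, and the step of a 20-fold lower number from compound 2 to compound 3 (1.29 log units; beyond the scatter) is large.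

Compound 4 `Cc1cncn1CCC(C(N)=O)(c1ccccc1)c1ccccc1` has not yet been measured. It differs from compound 3 in one place: 5-methyl-1H-imidazol-1-yl in place of 4,5-diethyl-1H-imidazol-1-yl on a saturated chain carbon, three bonds along the chain from two aromatic carbons and a carbonyl carbon. For the measured compounds named here, two measured steps bear on this change. The step of a 1.3-fold lower number from compound 1 to compound 3 (0.11 log units; within the scatter) shows that 4,5-diethyl-1H-imidazol-1-yl in place of 1H-imidazol-1-yl moved the number by nothing beyond the scatter. The step of a 15-fold higher number from compound 1 to compound 2 (1.19 log units; beyond the scatter) shows that 2-ethyl-1H-imidazol-1-yl in the same place raised the number greatly. Compound 4 carries 5-methyl-1H-imidazol-1-yl rather than 2-ethyl-1H-imidazol-1-yl, so the closer comparison is with compound 3 and compound 1, whose values lie within the scatter of each other. The expected step of a 1.3-fold higher number from compound 3 to compound 4 (0.10 log units; within the scatter) is therefore small, in no direction beyond the scatter. Compound 4 is expected to give 5 nM in this assay, with a range from 2 nM to 15 nM.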

Compound 4, antagonist equilibrium constant: 0.86 nM
For compound 4 the middle estimate is 5.8-fold (0.76 log units) above the measured one; measured number outside the range, below it.
By their numbers in this assay, from the lowest: compound 4; then compounds 3 and 1 (each within the scatter of the next); then compound 2.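

In this assay, the step from the unsubstituted group to 5-methyl-1H-imidazol-1-yl (a 5.9-fold lower number from compound 1 to compound 4 (0.77 log units; beyond the scatter)) shows that methyl in place of hydrogen on an aromatic carbon can lower the number beyond the scatter, whereas ethyl in place of hydrogen on an aromatic carbon in compound 2 raised it (a 15-fold higher number from compound 1 to compound 2 (1.19 log units; beyond the scatter)). The position therefore does not respond in one way to added alkyl groups: 5-methyl-1H-imidazol-1-yl also gives a lower number than 4,5-diethyl-1H-imidazol-1-yl (a 4.6-fold lower number from compound 3 to compound 4 (0.67 log units; beyond the scatter)) and a far lower number than 2-ethyl-1H-imidazol-1-yl (a 91-fold lower number from compound 2 to compound 4 (1.96 log units; beyond the scatter)), so the three substituted groups now differ clearly from one another. No measurement is available that would account for these differences.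

The compounds shown leave open whether the contrast follows the alkyl group or the ring carbon that carries it, as neither 2-methyl-1H-imidazol-1-yl nor 5-ethyl-1H-imidazol-1-yl is among them. They also leave open how the number would respond to a hydroxymethyl group or an amine on the ring carbon that bears the methyl in compound 4.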